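A few compounds are considered here, and "the series" means these few. Any claim that something is new, unique, unknown or untested is made for them only; others in the source may bear on it.

Compound 1 `COc1ccccc1C[C@H]1C(=O)OC[C@@H]1Cc1ccccc1` and compound 2 `O=C1OC[C@H](Cc2ccccc2)[C@H]1Cc1ccccc1OC(F)(F)F` share one core and differ in a single place: trifluoromethyl in place of methyl on an oxygen on an aromatic ring. In a functional assay on HL-60 cells (Homo sapiens) for cytotoxicity, read by WST assay, with a stated time of 48 h (on this read-out lower numbers stand for an effect already at smaller amounts and higher numbers for an effect only at larger amounts of compound), compound 1 gives 79000 nM, and compound 2 gives 39000 nM. The measured step is a 2.0-fold lower number from compound 1 to compound 2 (0.31 log units; beyond the scatter). Compound 3 `COc1cccc(C[C@H]2C(=O)OC[C@@H]2Cc2ccccc2)c1` is made of the same atoms as compound 1, joined differently, and the difference between the two cores is not broken down here. In this assay compound 3 gives 66000 nM, a value that lies within the scatter of both compound 1 and compound 2. Compound 4 `O=C1OC[C@H](Cc2ccccc2)[C@H]1Cc1cccc(OC(F)(F)F)c1` has not yet been measured. It differs from compound 3 in the same way that compound 2 differs from compound 1: trifluoromethyl in place of methyl on an oxygen on an aromatic ring. For the measured compounds named here, this change occurs twice among the four compounds, and its single measured step is the only guide available. Because the measured step was a 2.0-fold lower number from compound 1 to compound 2 (0.31 log units; beyond the scatter), a step of similar size is expected, and the estimated step is a 2.0-fold lower number from compound 3 to compound 4 (0.30 log units; within the scatter). Compound 4 is therefore expected to give about 33000 nM in this assay, with a likely range from 15000 nM to 70000 nM.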

Compound 4, half-maximal effective concentration: 34000 nM
Compound 4: the middle estimate sits 1.0-fold (0.01 log units) below what was measured; the range from low to high includes it.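

In this assay, putting trifluoromethyl in place of methyl on an oxygen on an aromatic ring gives a 1.9-fold lower number from compound 3 to compound 4 (0.29 log units; within the scatter), so this step taken alone is not a firm change. Set beside the earlier step, the change reads the same on both cores: the same change on two cores in this assay, a 2.0-fold lower number (0.31 log units; beyond the scatter) from compound 1 to compound 2 and a 1.9-fold lower number (0.29 log units; within the scatter) from compound 3 to compound 4, 1.0-fold (0.02 log units) apart, within the scatter of two such steps

This shows that, for these two pairs, the size of the step carried over from one core to the other, but two pairs do not make a rule for the whole series, and the numbers do not say why the step has this size. The compounds shown carry only methoxy or trifluoromethoxy on that ring, so it stays open how an amine, a carboxylic acid or a longer chain at the same place would read. On these data alone, whether the step would keep its size on a third core also stays open.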